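Methoxy to chloro on compound 3: expected step

The source may report more compounds than this note shows. Statements on the series, on what has been measured and on what is new or still open speak of the compounds shown alone.

Measured so far in an assay on cells with melanin-concentrating hormone receptor 1 (Homo sapiens) as the target, read by radioligand binding; on this read-out higher numbers stand for weaker inhibition and lower numbers for stronger inhibition:
- compound 1, `CC(CNCc1ccoc1)Oc1cccc2ccc(N)nc12`, gives 10 nM
- compound 2, `CC(C)c1ccc(CNCCCOc2cccc3ccc(N)nc23)cc1`, gives 10 nM
- compound 3, `COc1cccc(C(=O)NCCCOc2cccc3ccc(N)nc23)c1`, gives 2 nM

Compound 3 stands at the lowest number of the three in this assay; its gap to compound 1 and its gap to compound 2 are each beyond the scatter of the read-out. Compound 1 and compound 2 stand at the same number as each other. Among the measured compounds shown here, no pair among the measured compounds differs in one place only, so no measured step is available to read a trend from.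

Compound 4, `Nc1ccc2cccc(OCCCNC(=O)c3cccc(Cl)c3)c2n1`, is not yet measured. It differs from compound 3 by chloro in place of methoxy on an aromatic carbon of a six-membered aromatic ring of carbon only, meta to a large group; cut one bond further out, the difference reads 3-methoxyphenyl to 3-chlorophenyl.

For the measured compounds named here, with no step on record that bears on this change, the expectation for compound 4 is a step from compound 3 of about a 2.0-fold higher number from compound 3 to compound 4 (0.30 log units; within the scatter), which is no change beyond the scatter. On that basis compound 4 is estimated at 4 nM in this assay, with a range from 1.5 nM to 12 nM.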

Compound 4, half-maximal inhibitory concentration: 0.4 nM
The estimate for compound 4 lay 10-fold (1.00 log units) above the measured number; the measured number lies below the stated range.
By their numbers in this assay, from the lowest: compound 4; then compound 3; then compounds 1 and 2 (each within the scatter of the next).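

In this assay, among the compounds shown here, chloro in place of methoxy on an aromatic carbon, meta to a large group, gives a 5.0-fold lower number from compound 3 to compound 4 (0.70 log units; beyond the scatter), and this is the first change that can be read at a single place. The position therefore responds to its substituent, and in this pair the hydrogen-bond acceptor that leaves with methoxy is not needed for a low number, as a single chlorine atom in place of the two heavy atoms of methoxy brings compound 4 to 0.4 nM. Nothing on hand explains why the number falls, so the step stands as an observation on one pair of compounds.

Going by these compounds, one step does not separate what chloro brings from what is lost with methoxy, so it remains open how a hydrogen atom, methyl, trifluoromethyl or nitrile in the same place would compare on the 3-chlorophenyl amide framework of compound 4. Also open, on these data alone, is whether the same exchange gives a step of similar size on a different chain or linker, such as a longer chain between the amide and the shared core.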